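This account rests on a few compounds, and the source may have more. Where it says the series, first, only, none or still open, it means among the compounds named here.

Measured compounds:
compound 1, `O=C(Nc1cccc(/C=C/C(=O)c2nc3ccccc3[nH]2)c1)c1ccc(Cl)cc1`, 2270 nM
compound 2, `O=C(/C=C/c1cccc(NS(=O)(=O)c2cccc(Cl)c2)c1)c1nc2ccccc2[nH]1`, 737 nM

Going by the values given here, in a functional assay on HCT-116 cells (Homo sapiens) for antiproliferative activity, read by MTT assay, with a stated time of 48 h (on this read-out higher numbers stand for weaker inhibition and lower numbers for stronger inhibition), compound 2 gives the lower of the two numbers; the only measured step, a 3.1-fold lower number from compound 1 to compound 2 (0.49 log units; beyond the scatter), concerns the exchange of the linking group on the ring nitrogen and lies beyond the scatter. Compound 3, `Cc1ccccc1S(=O)(=O)Nc1cccc(/C=C/C(=O)c2nc3ccccc3[nH]2)c1`, differs from compound 2 by 2-methylphenyl in place of 3-chlorophenyl on a sulfonyl sulfur. No measured step touches the aryl group on the sulfonyl, so nothing shown bears directly on this change. For compound 3 the expected step is a 1.2-fold higher number from compound 2 to compound 3 (0.09 log units; within the scatter). Compound 3 is therefore estimated at 900 nM, in the range 300 nM to 3000 nM.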

Compound 3, half-maximal inhibitory concentration: 955 nM
Beside the measured number, compound 3's estimate is 1.1-fold (0.03 log units) below it; measured number inside the range.
By their numbers in this assay, from the lowest: compounds 2 and 3 (each within the scatter of the next); then compound 1.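

In this assay, the exchange on the sulfonyl sulfur gives a 1.3-fold higher number from compound 2 to compound 3 (0.11 log units; within the scatter) and so leaves the number unchanged within the scatter, with either 3-chlorophenyl or 2-methylphenyl tolerated at this position. The second sulfonyl compound also keeps its advantage over the carbonyl-linked compound, with a 2.4-fold lower number from compound 1 to compound 3 (0.38 log units; beyond the scatter) and so a step again beyond the scatter. No supporting evidence bears on these results. Still open, from the compounds shown here alone, is whether a pyridine ring or a methyl group on the sulfonyl sulfur would hold this level. Also open, going by these compounds, is how much of the gap to compound 1 belongs to the sulfonyl link alone, as its aryl group differs too.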